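Ethyl in place of nitro on the shared core

The source may hold more compounds than are shown below. What is called first, only, known or untested is meant among the compounds shown, and "the series" means these compounds.

- Compound 1 `CCc1ccc2c(c1)[C@@H](N1CCCCC1=O)[C@H](O)C2(C)C` gives 2780 nM
- Compound 2 `CC1(C)c2ccc([N+](=O)[O-])cc2[C@@H](n2ccccc2=O)[C@@H]1O` gives 150 nM

In a functional assay (trachea) for inhibition, with Cavia porcellus as the target (a lower number here means a stronger inhibitor, a higher number a weaker inhibitor), compound 2 (at 150 nM) has the lower of the two measured numbers, and its gap to compound 1 lies beyond the scatter. Compound 3 `CCc1ccc2c(c1)[C@@H](n1ccccc1=O)[C@H](O)C2(C)C` has not yet been measured. It carries ethyl in place of nitro on an aromatic carbon of compound 2 ethyl in place of nitro on an aromatic carbon and is otherwise the same. Among the measured compounds shown here, no step between measured compounds isolates this change, so the expectation rests on little. Compound 1 also carries ethyl and reads 2780 nM on the weaker side in this assay so compound 3 is expected to be a weaker inhibitor than compound 2. The expected step is a 5.3-fold higher number from compound 2 to compound 3 (0.73 log units; beyond the scatter) toward a higher number and beyond the scatter. Compound 3 is estimated at 800 nM with 250 nM to 2500 nM as its expected range.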

Compound 3, half-maximal inhibitory concentration: 2170 nM
The estimate for compound 3 lay 2.7-fold (0.43 log units) below the measured number, and the stated range covers the measured number.
By their numbers in this assay, from the lowest: compound 2; then compounds 3 and 1 (each within the scatter of the next).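

In this assay, the direct comparison puts a large cost on this change: ethyl in place of nitro on an aromatic carbon gives a 14-fold higher number from compound 2 to compound 3 (1.16 log units; beyond the scatter). With ethyl held fixed, exchanging the non-aromatic ring group on the saturated ring carbon for the aromatic one gives a 1.3-fold lower number from compound 1 to compound 3 (0.11 log units; within the scatter), which lies within the scatter, so the wide gap seen earlier belongs to the nitro-to-ethyl change and not to that exchange. No measurement shown here accounts for the effect of the nitro-to-ethyl change.

As far as these compounds go, it remains open whether the low number is particular to nitro or would also appear with a nitrile, a trifluoromethyl or an amine on that aromatic carbon. From the compounds shown here alone, it is also open whether the ring exchange would remain within the scatter with nitro on the shared core.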